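Dichlorophenyl versus methoxyphenyl on a shared allyl diketopiperazine core

This account rests on a few compounds, and the source may have more. Where it says the series, first, only, none or still open, it means among the compounds named here.

Measured compounds in a functional assay on HeLa cells (Homo sapiens) for cytotoxicity, read by CCK-8 assay, with a stated time of 72 h; on this read-out higher numbers stand for weaker inhibition and lower numbers for stronger inhibition:
compound 1 `C=CCn1c(=O)/c(=C\c2ccc(Cl)c(Cl)c2)[nH]c(=O)/c1=C\c1ccccc1OC`: "not active" (no number reported)
compound 2 `C=CCn1c(=O)/c(=C\c2ccccc2OC)[nH]c(=O)/c1=C\c1ccccc1OC`: 6900 nM
compound 3 `C=CCn1c(=O)/c(=C\c2ccccc2C(F)(F)F)[nH]c(=O)/c1=C\c1ccccc1OC`: 4600 nM

Compound 1 stands without a number: in this assay compound 1 is reported as "not active" (no number reported) only, so no scale is available for it. Compound 4 `C=CCn1c(=O)/c(=C\c2ccc(Cl)c(Cl)c2)[nH]c(=O)/c1=C\c1ccccc1` differs from compound 1 by hydrogen in place of methoxy on an aromatic carbon. Among the measured compounds shown here, the only measured step, a 1.5-fold lower number from compound 2 to compound 3 (0.18 log units; within the scatter), changes the same methoxy group but into trifluoromethyl, not hydrogen, and on a different pair of compounds; it bears only loosely on the step from compound 1 to compound 4. Since compound 1 gives no number, no step size can be projected. Compound 4 is expected, with wide uncertainty, near 20000 nM in this assay, between 5000 nM and 80000 nM, and a report of no activity is considered likely.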

Compound 4, half-maximal inhibitory concentration: "not active" (no number reported)
For compound 4 the study gives words and no number; no gap can be computed for the estimate.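

In this assay compound 1 gives "not active" (no number reported) and compound 4 gives "not active" (no number reported) so no step can be read between them. No further data bear on this result. The compounds shown leave open whether methoxy or hydrogen matters in this dichlorophenyl pair.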